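Urotensin receptor series: swapping the amide-bound aryl group

This account rests on a few compounds, and the source may have more. Where it says the series, first, only, none or still open, it means among the compounds named here.

Of the compounds shown here, two have been measured in an assay on HEK293 cells for binding affinity to Urotensin-2 receptor (Homo sapiens), read by radioligand binding; on this read-out higher numbers stand for weaker inhibition and lower numbers for stronger inhibition. Compound 1 `COc1ccc(C(=O)N[C@H]2CCN(Cc3ccc(OCCCN(C)C)cc3)C2)cc1OC` gives only a limit in this assay, < 10000 nM, so where it stands is known as a range and not as a number. Compound 2 `CN(C)CCCOc1ccc(CN2CC[C@H](NC(=O)c3ccccc3)C2)cc1` gives 2510 nM in this assay. The step that the limit leaves unreadable from compound 1 to compound 2 cannot be read as a size because of the limit of < 10000 nM in this assay, at which 1 of the 2 values shown sits.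

Compound 3 `CC(=O)N[C@@H](CC(C)C)C(=O)N[C@H]1CCN(Cc2ccc(OCCCN(C)C)cc2)C1` differs from compound 1 in one place: 1-acetamido-3-methylbutyl in place of 3,4-dimethoxyphenyl on a carbonyl carbon. Among the measured compounds shown here, the only measured step that touches the carbonyl substituent is the one from compound 1 to compound 2, and its size is unreadable, so no measured step gives a size or a direction for the change to compound 3. With compound 1 known only as a range, the expected step that the limit leaves unreadable from compound 1 to compound 3 is taken as no change beyond the scatter, with wide uncertainty on both sides. On that basis compound 3 is estimated to give 4000 nM in this assay, with a range from 400 nM to 30000 nM.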

Compound 3, inhibition constant: 2510 nM
The estimate for compound 3 lay 1.6-fold (0.20 log units) above the measured number; the measured number falls inside the stated range.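

Among the compounds shown here, the one readable new step on this carbonyl carbon is no change at the digits printed from compound 2 to compound 3 (within the scatter) in this assay, for 1-acetamido-3-methylbutyl in place of phenyl. Compounds 2 and 3 therefore show that, on a carbonyl carbon whose other neighbour is the amide-type nitrogen, a group with no ring and a defined stereocentre reads the same as a six-membered aromatic ring of carbon only, so a ring is not required here for binding at this level in this series. The steps that start at compound 1 still cannot be read, and the position of 3,4-dimethoxyphenyl relative to the other two groups stays unplaced, because of this limit: the limit of < 10000 nM in this assay, at which 1 of the 3 values shown sits.

Going by these compounds, what the acetamido part of compound 3 contributes stays open, and an amine in its place or a plain 3-methylbutyl chain on the carbonyl carbon would separate it from the rest of the group. Also open, on these data alone, is whether the defined stereocentre of 1-acetamido-3-methylbutyl matters, and whether a carboxylic acid or a longer chain at this place would move the value beyond the scatter.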